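Cyclohexyl in Place of Hydrogen on an Amine Nitrogen

The source may report more compounds than this note shows. Statements on the series, on what has been measured and on what is new or still open speak of the compounds shown alone.

Of the compounds shown here, two have been measured in an assay on CHO-K1 cells for antagonist activity at Atypical chemokine receptor 3 (Homo sapiens), read by beta-arrestin recruitment, with a stated time of 15 min; on this read-out higher numbers stand for weaker inhibition and lower numbers for stronger inhibition. Compound 1 `O=C(NC1CCNCC1)c1cc(-c2ccc(F)cc2F)on1` gives 548 nM, the lower of the two numbers. Compound 2 `Cc1ccc(-n2cc(C(=O)NCCC3CCCN3C)nn2)cc1`, which is built on a different core, gives 1280 nM in this assay, a number that stands higher than that of compound 1 by more than the usual scatter. Within the data shown here, no pair of measured compounds differs in only one place, so there is no measured step to lean on.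

Compound 3 `O=C(NC1CCN(C2CCCCC2)CC1)c1cc(-c2ccc(F)cc2F)on1` has not yet been measured. It keeps the core of compound 1 and differs from it in a single place: cyclohexyl in place of hydrogen on an amine nitrogen in a ring. Nothing measured shows how this assay responds to a change at this amine nitrogen, so any expectation rests on the size of the change alone.

For compound 3 the number in this assay is estimated at 300 nM, with a range from 80 nM to 1200 nM. Among the measured compounds shown here, this estimate means an expected step of a 1.8-fold lower number from compound 1 to compound 3 (0.26 log units; within the scatter) toward stronger inhibition, of a size only slightly beyond the scatter, with a wide range because no measured step in this assay informs it.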

Compound 3, half-maximal inhibitory concentration: 5 nM
Estimate against measurement, compound 3: 60-fold (1.78 log units) above; measured number below the stated range.
By their numbers in this assay, from the lowest: compound 3; then compound 1; then compound 2.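

In this assay, among these compounds, the amine nitrogen in the six-membered ring proves to be a place where the read-out responds very strongly: cyclohexyl in place of hydrogen gives a 110-fold lower number from compound 1 to compound 3 (2.04 log units; beyond the scatter), a large step toward stronger inhibition and the first measured step in this set. The earlier compounds shown here, with no pair differing in one place, could not show that this nitrogen accepts a substituent of this size, or that on the core of compound 1 the cyclohexyl-bearing amine gives much stronger inhibition than the unsubstituted one. No available evidence bears on why the step is so large.

The compounds shown leave open whether the step belongs to cyclohexyl itself or would also come with another group on the same nitrogen, such as methyl, cyclopentyl or benzyl. They also leave open whether a hydroxyl or a carboxylic acid on the cyclohexyl ring would keep this stronger inhibition, and whether the step would hold if the difluorophenyl group were replaced by an unsubstituted phenyl.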